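A few compounds are considered here, and "the series" means these few. Any claim that something is new, unique, unknown or untested is made for them only; others in the source may bear on it.

Measured compounds in this series:

compound 1, `COc1cc(C2CC(c3ccccc3)=NN2C(C)=O)ccc1O`, 7560 nM
compound 2, `CC(=O)N1N=C(c2ccco2)CC1c1cccc(O)c1`, 16500 nM
compound 3, `COc1ccc(OC)c(C2CC(c3ccco3)=NN2C(C)=O)c1`, 11200 nM

In a functional assay on PC-3 cells (Homo sapiens) for cytotoxicity, read by sulforhodamine B assay, with a stated time of 48 h (on this read-out lower numbers stand for stronger inhibition and higher numbers for weaker inhibition), compound 3 gives 11200 nM, the second highest of the three numbers. Its nearest neighbour is compound 2 at 16500 nM, and compound 1 at 7560 nM lies furthest away; both gaps are within the scatter, so no order among the three can be read from these values.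

Compound 4, `COc1cc(OC)c(C2CC(c3ccco3)=NN2C(C)=O)cc1OC`, has not been measured in this assay . It differs from compound 3 by methoxy in place of hydrogen on an aromatic carbon. Among the compounds with values here, no comparable step between measured compounds exists in this set to calibrate the change, so only a small shift, if any, beyond the scatter is expected; the step from compound 3 to compound 4 is expected to be a 1.2-fold lower number from compound 3 to compound 4 (0.09 log units; within the scatter). For compound 4 the expected value in this assay is 9000 nM, with a range from 3000 nM to 30000 nM.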

Compound 4, half-maximal inhibitory concentration: 8980 nM
Compound 4: the middle estimate sits 1.0-fold (0.00 log units) above what was measured, and the stated range covers the measured number.
By their numbers in this assay, from the lowest: compounds 1, 4, 3 and 2 (each within the scatter of the next, the first and the last beyond it).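

In this assay, methoxy in place of hydrogen on an aromatic carbon gives a 1.2-fold lower number from compound 3 to compound 4 (0.10 log units; within the scatter). This first single-place step in the series shows that this position, ortho to a methoxy group, meta to a methoxy group and para to a large group, accepts methoxy without a change beyond the scatter. No accompanying measurement bears on the reason for this result.

As far as these compounds go, whether an amine, a carboxylic acid or a longer chain at this position would move the number beyond the scatter remains open. Also open, from the compounds shown here alone, is whether the same methoxy step would hold on the core of compound 1.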